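This account rests on a few compounds, and the source may have more. Where it says the series, first, only, none or still open, it means among the compounds named here.

Measured in a functional assay on SGC-7901 cells (Homo sapiens) for antiproliferative activity, read by MTT assay, with a stated time of 72 h; on this read-out lower numbers stand for stronger inhibition and higher numbers for weaker inhibition:
Compound 1 `COc1ccccc1-c1ccc2ncn(-c3cc(OC)c(OC)c(OC)c3)c2c1`: 5050 nM
Compound 2 `COc1cc(-n2cnc3ccc(-c4cccc(F)c4)cc32)cc(OC)c1OC`: 2490 nM

Compound 2 holds the lower of these two numbers, so it is the stronger inhibitor so far. Compound 3 `COc1cc(-n2cnc3ccc(-c4cccc(C)c4C)cc32)cc(OC)c1OC` carries 2,3-dimethylphenyl in place of 3-fluorophenyl on an aromatic carbon. Among the compounds with values here, only one measured step bears on this, a swap of one aromatic group for another on the same carbon: a 2.0-fold lower number from compound 1 to compound 2 (0.31 log units; beyond the scatter), which is modest but beyond the scatter. With a single step as a guide, a similarly modest move towards a higher number is expected in this assay, and the estimate is a 1.4-fold higher number from compound 2 to compound 3 (0.15 log units; within the scatter). For compound 3 the estimated value is 3500 nM, with an expected range from 1200 nM to 10000 nM.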

Compound 3, half-maximal inhibitory concentration: 3040 nM
Beside the measured number, compound 3's estimate is 1.2-fold (0.06 log units) above it; the measured number falls inside the stated range.
By their numbers in this assay, from the lowest: compounds 2, 3 and 1 (each within the scatter of the next, the first and the last beyond it).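

In this assay, 2,3-dimethylphenyl at this aromatic carbon gives numbers within the scatter of both earlier groups (a 1.2-fold higher number from compound 2 to compound 3 (0.09 log units; within the scatter); a 1.7-fold lower number from compound 1 to compound 3 (0.22 log units; within the scatter)). A ring of carbon only with two methyl groups therefore cannot be told apart here from 3-fluorophenyl or from 2-methoxyphenyl, even though those two groups differ from each other beyond the scatter. Nothing measured here explains this closeness.

Still open, going by these compounds, is whether the numbers at this position would shift with something other than a substituted phenyl ring, such as an amine or a carboxylic acid.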